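The compounds below may be only part of what the source reports. "The series", "measured", "known", "first", "only" and "open" are said of these compounds alone.

In an ADME assay on MRC5 cells (Homo sapiens) for cytotoxicity, read by fluorescence and resazurin assay, with a stated time of 3 days (on this read-out higher numbers stand for an effect only at larger amounts of compound and lower numbers for an effect already at smaller amounts), compound 1 `O=C1C=CC(O)(c2nc3ccccc3s2)C(Cl)=C1` gives 55 nM and compound 2 `CCOC(=O)Nc1ccc(S(=O)(=O)n2c(C3(O)C=CC(=O)C=C3)cc3ccccc32)cc1` gives 86 nM. Going by the values given here, these two values lie within the usual scatter of each other, so compound 2 stands level with the only other measured compound.

Compound 3 `CN1CCN(C(=O)CCc2ccc(S(=O)(=O)n3c(C4(O)C=CC(=O)C=C4)cc4ccccc43)cc2)CC1`, not yet measured, differs from compound 2 in one place. There, 2-((4-methylpiperazin-1-yl)carbonyl)ethyl stands in place of (ethoxycarbonyl)amino on an aromatic carbon, para to a large group (2-((4-methylpiperazin-1-yl)carbonyl)ethyl in place of (ethoxycarbonyl)amino on an aromatic carbon).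

Among the compounds with values here, no measured pair shows this change on its own, so the data give no direct size for it. Compound 1 at 55 nM and compound 2 at 86 nM differ in far more than one place, yet remain within the scatter. The expected outcome is therefore no shift beyond the scatter in this assay, and the estimated 1.2-fold higher number from compound 2 to compound 3 (0.07 log units; within the scatter) has no firm direction. The estimate for compound 3 is 100 nM, with an expected range of 35 nM to 300 nM.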

Compound 3, half-maximal effective concentration: 52 nM
Estimate against measurement, compound 3: 1.9-fold (0.28 log units) above, within the range that was stated.
By their numbers in this assay, from the lowest: compounds 3, 1 and 2 (each within the scatter of the next).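

At this aromatic carbon, para to a large group, 2-((4-methylpiperazin-1-yl)carbonyl)ethyl in place of (ethoxycarbonyl)amino gives a 1.7-fold lower number from compound 2 to compound 3 (0.22 log units; within the scatter) in this assay. This single-place comparison, the only one shown, indicates that a group of 11 heavy atoms with a six-membered non-aromatic ring and 0 hydrogen-bond donors can replace one of 6 heavy atoms with no ring and 1 hydrogen-bond donor without a shift beyond the scatter. Nothing in the information at hand explains why the read-out stays level across this change.

As far as these compounds go, it remains open whether a carboxylic acid or a simple amine at this carbon would also stay within the scatter. A longer chain leading to the 4-methylpiperazine ring is equally untested by these compounds, so a single step cannot define how much this position tolerates.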